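The compounds below may be only part of what the source reports. "The series", "measured", "known", "first", "only" and "open" are said of these compounds alone.

Compound 1 `CC(C)(C)c1ccc(C(=O)N2CCC3(CC2)C(=O)N(CC(=O)N2CCC(CCO)CC2)CN3c2ccccc2)cc1` was tested in an assay on HEK293 cells for displacement of a labelled ligand from NPC1-like intracellular cholesterol transporter 1 (Homo sapiens) (on this read-out higher numbers stand for weaker inhibition and lower numbers for stronger inhibition), where compound 1 gives 2600 nM. Among the three measured compounds this value is the second highest: compound 3 `CC(C)(C)OC(=O)NCC1CCCN(C(=O)CN2CN(c3ccccc3)C3(CCN(C(=O)c4ccc(C5CCCCC5)cc4)CC3)C2=O)C1` gives 3800 nM, which lies within the scatter of compound 1, while compound 2 `CCOC(=O)C1CCN(C(=O)CN2CN(c3ccccc3)C3(CCN(C(=O)c4ccc(C5CCCCC5)cc4)CC3)C2=O)CC1` gives 900 nM, a number beyond the scatter from compound 1. Compound 4 `CC(C)(C)c1ccc(C(=O)N2CCC3(CC2)C(=O)N(CC(=O)N2CCCCC2CCO)CN3c2ccccc2)cc1` has not yet been measured in this assay. It differs from compound 1 by 2-(2-hydroxyethyl)piperidin-1-yl in place of 4-(2-hydroxyethyl)piperidin-1-yl on a carbonyl carbon. Among the measured compounds shown here, no measured pair shows this change, so nothing in the data indicates its direction. The step from compound 1 to compound 4 is estimated as a 1.2-fold higher number from compound 1 to compound 4 (0.06 log units; within the scatter), expected to stay within the scatter. Compound 4 is therefore expected to give about 3000 nM in this assay, with a range from 1200 nM to 8000 nM.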

Compound 4, half-maximal inhibitory concentration: 6100 nM
For compound 4 the middle estimate is 2.0-fold (0.31 log units) below the measured one; measured number inside the range.
By their numbers in this assay, from the lowest: compound 2; then compounds 1, 3 and 4 (each within the scatter of the next, the first and the last beyond it).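

In this assay, 2-(2-hydroxyethyl)piperidin-1-yl in place of 4-(2-hydroxyethyl)piperidin-1-yl on the carbonyl carbon gives a 2.3-fold higher number from compound 1 to compound 4 (0.37 log units; beyond the scatter). Among the compounds shown here, this is the first pair here that differs in one place, and it shows that this position responds to a change that leaves the atoms the same and only joins them differently. Nothing available explains this step. On these data alone, it remains open how 3-(2-hydroxyethyl)piperidin-1-yl would compare with these two groups. Also open, as far as these compounds go, is whether a carboxylic acid or an amine at the end of the chain, in place of the hydroxyl, would change the number.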